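The compounds below may be only part of what the source reports. "The series", "measured", "known", "first", "only" and "open" are said of these compounds alone.

In a functional assay on HCT-116 cells (Homo sapiens) for antiproliferative activity, read by MTT assay, with a stated time of 24 h (on this read-out lower numbers stand for stronger inhibition and higher numbers for weaker inhibition), compound 1 `C=CCOc1ccc2c(=O)c(-c3cc(OC)c(OC)cc3OC)coc2c1` gives 6600 nM and compound 2 `COc1cc(OC)c(-c2coc3cc(OCc4ccccc4C)ccc3c2=O)cc1OC` gives 2900 nM. Compound 3 `COc1cc(OC)c(-c2coc3cc(OCc4ccc([N+](=O)[O-])cc4)ccc3c2=O)cc1OC` gives > 10000 nM, which is a limit of the assay and not a number. Compound 4 `COc1cc(OC)c(-c2coc3cc(OCc4cccc(Cl)c4)ccc3c2=O)cc1OC` carries 3-chlorophenyl in place of 4-nitrophenyl on a saturated chain carbon bound to an oxygen on an aromatic ring. For the measured compounds named here, two measured steps bear on this change, both ending at the 4-nitrophenyl group of compound 3: an at least 3.4-fold higher number from compound 2 to compound 3 (0.53 log units; beyond the scatter), and an at least 1.5-fold higher number from compound 1 to compound 3 (0.18 log units; that floor lies within the scatter). Going by the values given here, no measured compound carries 3-chlorophenyl, so the expectation rests on these steps alone. A modest move to a lower number is expected, an estimated at least 2.5-fold lower number from compound 3 to compound 4 (0.39 log units; beyond the scatter). The estimate for compound 4 is 4000 nM, within an expected range of 1500 nM to 10000 nM.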

Compound 4, half-maximal inhibitory concentration: 1330 nM
Compound 4: middle estimate off by 3.0-fold (0.48 log units), on the high side; measured number outside the range, below it.
By their numbers in this assay, from the lowest: compound 4; then compound 2; then compound 1. At a limit, above all of these: compound 3.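

In this assay, for the compounds shown here, 3-chlorophenyl on the saturated chain carbon bound to an oxygen on an aromatic ring gives the lowest number so far, with a 2.2-fold lower number from compound 2 to compound 4 (0.34 log units; beyond the scatter) and a 5.0-fold lower number from compound 1 to compound 4 (0.70 log units; beyond the scatter). The phenyl groups at this place now lie further apart, with an at least 7.5-fold lower number from compound 3 to compound 4 (0.87 log units; beyond the scatter). That step is only a floor, as the value of compound 3 is a limit of the assay and not a number: the limit of > 10000 nM in this assay, at which 1 of the 4 values shown sits.

The compounds shown leave open whether 3-chlorophenyl owes its result to the chlorine itself. They also leave open how a phenyl ring bearing a methoxy group, an amine or a carboxylic acid would read here.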